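The compounds below may be only part of what the source reports. "The series", "measured", "known", "first", "only" and "open" are said of these compounds alone.

Compound 1 `COc1ccc(C2=NN(C(=O)c3cccnc3)C(c3cn(C)c4ccc(Br)cc34)C2)cc1` carries the shared core with a pyridin-3-yl carbonyl group on one nitrogen. In a functional assay on MCF7 cells (Homo sapiens) for inhibition, read by MTT assay, with a stated time of 48 h (on this read-out higher numbers stand for weaker inhibition of growth and lower numbers for stronger inhibition of growth), compound 1 gives 1560 nM. Compound 2 `COc1ccc(C2=NN(C(=O)c3cccnc3)C(c3cn(C)c4ccc(Br)cc34)C2)cc1OC` differs from compound 1 by one change, (methoxy in place of hydrogen on an aromatic carbon), and in this assay compound 2 gives 1170 nM, so that a 1.3-fold lower number from compound 1 to compound 2 (0.12 log units; within the scatter).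

Compound 3 `COc1ccc2c(c1)c(C1CC(c3ccccc3)=NN1C(=O)c1cccnc1)cn2C` has a different core; the difference between the two cores is not broken down here. In this assay compound 3 gives 1160 nM.

Compound 4 `COc1ccc2c(c1)c(C1CC(c3ccccc3)=NN1C(=O)c1ccc(OC)nc1)cn2C` has not yet been measured. It differs from compound 3 by methoxy in place of hydrogen on an aromatic carbon. Within the data shown here, this is the same kind of change as the one from compound 1 to compound 2, but the place differs: there it sat on a six-membered aromatic ring of carbon only, ortho to a methoxy group and meta to a large group, while here it sits on a six-membered aromatic ring with 1 nitrogen, next to the ring nitrogen and para to a large group.

Because the earlier methoxy addition gave a 1.3-fold lower number from compound 1 to compound 2 (0.12 log units; within the scatter), the step from compound 3 to compound 4 is expected to be small as well, a 1.2-fold lower number from compound 3 to compound 4 (0.06 log units; within the scatter). In this assay compound 4 is therefore estimated at 1000 nM, most likely between 450 nM and 2300 nM.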

Compound 4, concentration for 50% growth inhibition: 990 nM
Estimate against measurement, compound 4: 1.0-fold (0.00 log units) above; the measured number falls inside the stated range.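

In this assay, turning pyridin-3-yl into 6-methoxypyridin-3-yl gives a 1.2-fold lower number from compound 3 to compound 4 (0.07 log units; within the scatter) and so makes no change that can be told apart from the usual scatter of repeated measurements. Set beside the earlier methoxy addition on the other core, the two steps agree: the same change on two cores in this assay, a 1.3-fold lower number (0.12 log units; within the scatter) from compound 1 to compound 2 and a 1.2-fold lower number (0.07 log units; within the scatter) from compound 3 to compound 4, 1.1-fold (0.06 log units) apart, within the scatter of two such steps. This shows that in these two cases the methoxy group left the number much as it was, but the agreement rests on two very small steps at different places on different rings, so it does not show that the methoxy group strengthens growth inhibition or that it would do the same on any further core in the series.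

The compounds shown leave open whether another group at the place of this methoxy group, such as an amine or a longer chain like butoxy, would move the number beyond the scatter. They also leave open what the methoxy group would do at other places on the pyridin-3-yl ring.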